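Replacing the Group on the Ring Amine Nitrogen

This account rests on a few compounds, and the source may have more. Where it says the series, first, only, none or still open, it means among the compounds named here.

Measured so far in an assay on a protein complex for displacement of a labelled ligand from CDK8/Cyclin C (Homo sapiens), read by TR-FRET, with a stated time of 1 h; on this read-out lower numbers stand for stronger inhibition and higher numbers for weaker inhibition:
Compound 1 `CNc1nccc(N2CC[C@H](NC(=O)Nc3ccc(CN(C)C)c(C(F)(F)F)c3)C2)n1`: 40.1 nM
Compound 2 `CNc1nccc(N2CC[C@H](NC(=O)Nc3ccc(Cl)c(C(F)(F)F)c3)C2)n1`: 10.1 nM

Compound 2 stands at the lowest number of the two. Among the compounds with values here, the only measured step, a 4.0-fold lower number from compound 1 to compound 2 (0.60 log units; beyond the scatter), concerns a chloro replacing a (dimethylamino)methyl group on an aromatic carbon, and it places compound 2 below compound 1 by more than the usual scatter.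

Compound 3 `O=C(Nc1ccc(Cl)c(C(F)(F)F)c1)N[C@H]1CCN(c2ccc3nncn3n2)C1` differs from compound 2 in a different place: a group of 9 heavy atoms (5 carbon, 4 nitrogen; one five-membered aromatic ring with 3 hetero atoms, one six-membered aromatic ring with 2 hetero atoms) in place of a group of 8 heavy atoms (5 carbon, 3 nitrogen; one six-membered aromatic ring with 2 hetero atoms), on an amine nitrogen in a ring. Within the data shown here, no measured step touches the group on the amine nitrogen in the ring, so the one step seen gives no guide to the size or direction of this change. Compound 3 is therefore expected to sit near compound 2, with a wide range on either side, an estimated step of a 3.0-fold higher number from compound 2 to compound 3 (0.47 log units; beyond the scatter). The estimate for compound 3 is 30 nM, between 5 nM and 200 nM.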

Compound 3, half-maximal inhibitory concentration: 4.2 nM
For compound 3 the middle estimate is 7.1-fold (0.85 log units) above the measured one; measured number below the stated range.
By their numbers in this assay, from the lowest: compound 3; then compound 2; then compound 1.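

In this assay, exchanging the 2-(methylamino)pyrimidin-4-yl group on the amine nitrogen in the ring for a group with one five-membered and one six-membered aromatic ring gives a 2.4-fold lower number from compound 2 to compound 3 (0.38 log units; beyond the scatter). This position therefore accepts a group of a different shape, and the number still goes down rather than up. The entering group has 0 hydrogen-bond donors where the leaving group has 1, so in this series a donor in that group is not needed to reach a number as low as that of compound 3, and no measurement at hand explains the gain.

On these data alone, it remains open whether the same exchange would lower the number if the chloro were replaced by the (dimethylamino)methyl group of compound 1. Also open, as far as these compounds go, is how a single pyridine ring or a saturated morpholine ring would behave on this nitrogen.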